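Cytotoxicity notes on amide-tail variants of the shared core

The compounds below may be only part of what the source reports. "The series", "measured", "known", "first", "only" and "open" are said of these compounds alone.

Compound 1, `Cc1cc(C)cc(S(=O)(=O)c2c(C(=O)NC(C)C(=O)NC(C)c3ccncc3)[nH]c3ccc(Cl)cc23)c1`, gives 21900 nM in an ADME assay on MT4 cells (Homo sapiens) for cytotoxicity, read by MTT assay; a higher number here means that more compound is tolerated, a lower number that less compound is tolerated.
Compound 2, `Cc1cc(C)cc(S(=O)(=O)c2c(C(=O)NC(C)C(=O)NCc3ccccc3F)[nH]c3ccc(Cl)cc23)c1`, gives 23300 nM in this assay.
Compound 3, `Cc1cc(C)cc(S(=O)(=O)c2c(C(=O)NC(C)C(=O)NCc3ccncc3)[nH]c3ccc(Cl)cc23)c1`, gives 19500 nM in this assay.

Compound 3 stands level with the other two: a 1.1-fold lower number from compound 1 to compound 3 (0.05 log units; within the scatter) and a 1.2-fold lower number from compound 2 to compound 3 (0.08 log units; within the scatter), neither step reaching beyond the scatter. Across the three compounds the amide tail has been varied without any change in this assay that can be read as real; a 1.1-fold higher number from compound 1 to compound 2 (0.03 log units; within the scatter) is likewise within the scatter.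

Compound 4, `Cc1cc(C)cc(S(=O)(=O)c2c(C(=O)NC(C)C(=O)NC(C)c3ccccc3F)[nH]c3ccc(Cl)cc23)c1`, is not yet measured. It differs from compound 3 in one place: 1-(2-fluorophenyl)ethyl in place of (pyridin-4-yl)methyl on an amide-type nitrogen. For the measured compounds named here, two measured steps bear on it. The ring swap itself is covered by the step from compound 2 to compound 3, a 1.2-fold lower number from compound 2 to compound 3 (0.08 log units; within the scatter), taken in reverse. The added methyl on the saturated chain carbon is covered by the step from compound 1 to compound 3, a 1.1-fold lower number from compound 1 to compound 3 (0.05 log units; within the scatter), also in reverse. Both are within the scatter, so no step beyond the scatter is expected in this assay for compound 4, in either direction; the expected step is a 1.1-fold higher number from compound 3 to compound 4 (0.03 log units; within the scatter).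

Compound 4 is therefore estimated at 21000 nM in this assay, with a range from 12000 nM to 38000 nM.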

Compound 4, half-maximal cytotoxic concentration: 15200 nM
The estimate for compound 4 lay 1.4-fold (0.14 log units) above the measured number, within the range that was stated.
By their numbers in this assay, from the lowest: compounds 4, 3, 1 and 2 (each within the scatter of the next).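

The tail on the amide-type nitrogen still has no effect that can be read in this assay, even with the methyl on the saturated chain carbon and the 2-fluorophenyl ring now combined in 1-(2-fluorophenyl)ethyl: the steps are a 1.3-fold lower number from compound 3 to compound 4 (0.11 log units; within the scatter) and a 1.5-fold lower number from compound 2 to compound 4 (0.19 log units; within the scatter) and a 1.4-fold lower number from compound 1 to compound 4 (0.16 log units; within the scatter) and all stay within the scatter. The methyl change can now be read on two cores, and the two readings do not differ by more than the scatter: the same change on two cores in this assay, a 1.1-fold lower number (0.05 log units; within the scatter) from compound 1 to compound 3 and a 1.5-fold higher number (0.19 log units; within the scatter) from compound 4 to compound 2, 1.7-fold (0.24 log units) apart, within the scatter of two such steps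

The exchange of pyridin-4-yl for 2-fluorophenyl can also be read twice, with the same outcome, so these four compounds show no sign that either change depends on the other: the same change on two cores in this assay, a 1.2-fold lower number (0.08 log units; within the scatter) from compound 2 to compound 3 and a 1.4-fold higher number (0.16 log units; within the scatter) from compound 4 to compound 1, 1.7-fold (0.24 log units) apart, within the scatter of two such steps

All four compounds share one core and span only aromatic tails with or without the methyl, so these data cannot say how far this position tolerates change. On these data alone, whether an amine, a carboxylic acid or a longer chain on the amide-type nitrogen would produce a step beyond the scatter in this assay remains open, as does the effect of any change to the shared core.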